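The compounds below may be only part of what the source reports. "The series", "measured", "known", "first", "only" and "open" are said of these compounds alone.

Compound 1 `COc1ccc(Cn2c(CCc3ccccc3)nnc2[C@H](NC(=O)C(C)(C)N)c2c[nH]c3ccccc23)cc1` gives 5 nM in a functional assay on CHO cells for antagonist activity at growth hormone secretagogue receptor type 1 (Homo sapiens); a lower number here means a stronger inhibitor, a higher number a weaker inhibitor. Within the data shown here, compound 2 `COc1ccc(Cn2c(CCc3ccccc3)nnc2[C@H](NC(=O)C(C)(C)N)c2c[nH]c3ccccc23)c(OC)c1` gives 17 nM in this assay, the higher of the two numbers measured so far, and the one measured step, a 3.4-fold higher number from compound 1 to compound 2 (0.53 log units; beyond the scatter), is what separates them. Compound 3 `COc1ccc(Cn2c(CCc3ccccc3)nnc2[C@H](NC(=O)c2cnccn2)c2c[nH]c3ccccc23)c(OC)c1` differs from compound 2 by pyrazin-2-yl in place of 1-amino-1-methylethyl on a carbonyl carbon. Among the measured compounds shown here, no measured step touches the group on this carbonyl carbon, so the single known step gives no guide to the size or direction of the change. Compound 3 is expected to give about 40 nM, in the range 6 nM to 300 nM. The step expected is a 2.4-fold higher number from compound 2 to compound 3 (0.37 log units; beyond the scatter).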

Compound 3, antagonist equilibrium constant: 24 nM
For compound 3 the middle estimate is 1.7-fold (0.22 log units) above the measured one; the range from low to high includes it.
By their numbers in this assay, from the lowest: compound 1; then compounds 2 and 3 (each within the scatter of the next).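

In this assay, the step of a 1.4-fold higher number from compound 2 to compound 3 (0.15 log units; within the scatter) shows that pyrazin-2-yl can stand in place of 1-amino-1-methylethyl on this carbonyl carbon without a change beyond the scatter. The group that leaves has a hydrogen-bond donor and no ring, while the group that enters has no donor and an aromatic ring, so a donor in this group is not required for a number in this range. No available evidence gives a reason for this result.

As far as these compounds go, it remains open how a phenyl ring, a pyridine ring or a carboxylic acid would fare on this carbonyl carbon. Also open, from the compounds shown here alone, is whether pyrazin-2-yl behaves the same way on the core of compound 1.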